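Removing the methoxy from compound 3: expected tolerance

The compounds below may be only part of what the source reports. "The series", "measured", "known", "first", "only" and "open" are said of these compounds alone.

Values in a toxicity assay on THP-1 cells (Homo sapiens) for inhibition; a higher number here means that more compound is tolerated, a lower number that less compound is tolerated
compound 1 `COc1ccc(-c2cnc(NC(=O)c3ncc[nH]3)n2C)cc1` gives > 100000 nM
compound 2 `Cn1c(-c2ccc(Cl)cc2)cnc1NC(=O)c1ncc[nH]1` gives 52000 nM
compound 3 `COc1cccc(-c2cnc(NC(=O)c3ncc[nH]3)n2C)c1` gives > 100000 nM

Compound 3 stands at > 100000 nM as a limit of the assay and not a number. Compound 1 gives > 100000 nM which is likewise a limit. Across the series the picture is the limit of > 100000 nM in this assay, at which 2 of the 3 values shown sit, as things stand. Only compound 2 at 52000 nM carries a number.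

Compound 4 `Cn1c(-c2ccccc2)cnc1NC(=O)c1ncc[nH]1` is not yet measured. It differs from compound 3 by hydrogen in place of methoxy on an aromatic carbon with hydrogen in place of methoxy on an aromatic carbon. For the measured compounds named here, the one measured step that bears on this is an at least 1.9-fold lower number from compound 1 to compound 2 (0.28 log units; that floor lies within the scatter) and it also takes away a methoxy, though chloro enters there and not hydrogen. Going by that step and compound 2 at 52000 nM no step beyond the scatter is expected in this assay. Compound 4 may be reported only as a limit. The expected change is a number no higher from compound 3 to compound 4 (the limit leaves the size open) in this estimate. For compound 4 the estimated value is 100000 nM with an expected range from 45000 nM to 200000 nM for now.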

Compound 4, half-maximal cytotoxic concentration: > 100000 nM
Compound 4: only a limit was reported; the forecaster's own chance of this, stated with the estimate: 60%; the middle value sits exactly at the limit.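

In this assay compound 4 gives > 100000 nM, which is a limit of the assay and not a number, so a methoxy on the six-membered aromatic ring is not required for a value at this limit. The steps to compound 4 from compound 1 and from compound 3 cannot be read, with limits at both ends. Hydrogen in place of chloro gives an at least 1.9-fold higher number from compound 2 to compound 4 (0.28 log units; that floor lies within the scatter), so hydrogen and chloro cannot be told apart at this level of scatter.

How far tolerance extends for compound 1, compound 3 and compound 4 stays unresolved: the limit of > 100000 nM in this assay, at which 3 of the 4 values shown sit.

From the compounds shown here alone, whether an amine or a carboxylic acid on this aromatic carbon would give a number rather than a limit in this assay stays open.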